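Trimming the Isobutyl Chain of Compound 2

The source may hold more compounds than are shown below. What is called first, only, known or untested is meant among the compounds shown, and "the series" means these compounds.

Compound 1 `CCCC(Oc1ccc(-n2cc3ccccc3n2)cc1)c1ccc(C(=O)NCCC(=O)O)cc1` gives 2.5
Compound 2 `CC(C)CC(Oc1ccc(-n2cc(C(F)(F)F)cn2)cc1)c1ccc(C(=O)NCCC(=O)O)cc1` gives 3.2

In a physicochemical assay for lipophilicity, using the shake flask method, at pH 7.4 (a lower number here means a more polar compound, a higher number a more lipophilic compound), compound 2 stands highest of the two, above compound 1 by more than the usual scatter. Compound 3 `CCCC(Oc1ccc(-n2cc(C(F)(F)F)cn2)cc1)c1ccc(C(=O)NCCC(=O)O)cc1` differs from compound 2 by hydrogen in place of methyl on a saturated chain carbon bound to two saturated chain carbons with hydrogen in place of methyl on a saturated chain carbon bound to two saturated chain carbons. Isobutyl thus becomes propyl. Among the compounds with values here, no measured pair shows this change alone, so its size remains a judgement. A small downward step in this assay is expected, and the estimate is a number 0.40 log units lower from compound 2 to compound 3 (beyond the scatter) as a modest move beyond the scatter. In this assay compound 3 is estimated at 2.8 with 2.4 to 3.1 as its likely range.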

Compound 3, distribution coefficient: 2.4
The estimate for compound 3 lay 0.40 log units above the measured number, within the range that was stated.
By their numbers in this assay, from the lowest: compounds 3 and 1 (each within the scatter of the next); then compound 2.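

Taking the methyl off a saturated chain carbon bound to two saturated chain carbons, so that isobutyl becomes propyl, gives a number 0.80 log units lower from compound 2 to compound 3 (beyond the scatter) in this assay, which puts a measured size on this single change. With the propyl chain in both compounds, 4-(trifluoromethyl)-1H-pyrazol-1-yl in place of 2H-indazol-2-yl on an aromatic carbon gives a number 0.10 log units lower from compound 1 to compound 3 (within the scatter) in this assay, so these two groups cannot be told apart here. Nothing available explains the size of the chain step. Still open, going by these compounds, is where a butyl chain, or a propyl chain carrying an amine, would fall in this assay.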